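A few compounds are considered here, and "the series" means these few. Any claim that something is new, unique, unknown or untested is made for them only; others in the source may bear on it.

Measured so far in a functional assay on the whole organism with Mus musculus as the target, in the rotarod test; on this read-out higher numbers stand for an effect only at larger amounts of compound and lower numbers for an effect already at smaller amounts:

- compound 1, `CN(C)CC(=O)NCC(=O)N(C)c1ccc(Cl)cc1C(=O)c1ccccc1Cl`, gives 26 mg/kg.
- compound 2, `CN1CCN(CC(=O)NCC(=O)N(C)c2ccc(Cl)cc2C(=O)c2ccccc2Cl)CC1`, gives > 100 mg/kg, which is a limit of the assay and not a number.
- compound 3, `CCCCC(=O)NCC(=O)N(C)c1ccc(Cl)cc1C(=O)c1ccccc1Cl`, gives 90 mg/kg.

Compound 1 holds the lowest of the two numbers shown; its nearest neighbour is compound 3, with a 3.5-fold higher number from compound 1 to compound 3 (0.54 log units; beyond the scatter). Compound 2 sits at the limit of > 100 mg/kg in this assay, at which 1 of the 3 values shown sits.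

The next compound is compound 4, `CN(C(=O)CNC(=O)CN1CCCCC1)c1ccc(Cl)cc1C(=O)c1ccccc1Cl`. Against compound 1 the change is piperidin-1-yl in place of dimethylamino on a saturated chain carbon bound to a carbonyl carbon. Two measured steps replace dimethylamino at the same place, and both raise the number: a 3.5-fold higher number from compound 1 to compound 3 (0.54 log units; beyond the scatter) and an at least 3.8-fold higher number from compound 1 to compound 2 (0.58 log units; beyond the scatter). Between compound 2 and compound 3 the numbers show an at least 1.1-fold lower number from compound 2 to compound 3 (0.04 log units; that floor lies within the scatter), which is inside the scatter. Neither measured replacement matches piperidin-1-yl exactly, so the expected step is taken as moderate and upward: a 2.1-fold higher number from compound 1 to compound 4 (0.33 log units; beyond the scatter). Compound 4 is therefore estimated at 55 mg/kg, with a range from 25 mg/kg to 120 mg/kg, and some chance that this assay reports only a limit.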

Compound 4, dose for half-maximal effect: > 100 mg/kg
Compound 4 gave a limit, no number; the forecaster's own chance of this, stated with the estimate: 20%; at least 1.8-fold (0.25 log units) between middle value and limit.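

In this assay compound 4 gives > 100 mg/kg, which is a limit of the assay and not a number. The piperidin-1-yl ring at this place, on a saturated chain carbon bound to a carbonyl carbon, gives an at least 3.8-fold higher number from compound 1 to compound 4 (0.58 log units; beyond the scatter), so among the groups shown, a six-membered ring without a second nitrogen also fails to keep the number of dimethylamino. The step of an at least 1.1-fold higher number from compound 3 to compound 4 (0.04 log units; that floor lies within the scatter) has a floor within the scatter, and the step between compound 2 and compound 4 cannot be read, with both now at the same limit: the limit of > 100 mg/kg in this assay, at which 2 of the 4 values shown sit.

From the compounds shown here alone, how far the number rises for compound 2 and compound 4 stays unknown. Going by these compounds, whether diethylamino, pyrrolidin-1-yl or an unsubstituted amino group at this place would stay close to compound 1 also remains open.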